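The source may report more compounds than this note shows. Statements on the series, on what has been measured and on what is new or still open speak of the compounds shown alone.

Compound 1 `Cn1c(Cc2nn(C)c(=O)c3ccccc23)nnc1SCCCCCCCC(=O)Nc1ccc(Cl)cc1Cl` gives 3900 nM in an assay on 32D cells for inhibition of interleukin-15 (Mus musculus), read by resazurin assay, with stated times of 30 min and 2.5 days, in the presence of a further agent that is not named here (a lower number here means a stronger inhibitor, a higher number a weaker inhibitor), the highest of the two numbers shown. Compound 2 `Cn1nc(Cc2nnc(SCCCCCCCC(=O)Nc3ccc(Cl)cc3Cl)[nH]2)c2ccccc2c1=O` gives 3500 nM in this assay, and the step of a 1.1-fold lower number from compound 1 to compound 2 (0.05 log units; within the scatter) stays within the scatter. Compound 3 `Cn1nc(Cc2nnc(SCCCCCCCC(=O)Nc3ccc(Cl)cc3Cl)n2CCC(=O)O)c2ccccc2c1=O` reaches only the limit of > 30000 nM in this assay. That limit is the limit of > 30000 nM in this assay, at which 1 of the 3 values shown sits. The step of an at least 7.6-fold higher number from compound 1 to compound 3 (0.88 log units; beyond the scatter) and the step of an at least 8.5-fold higher number from compound 2 to compound 3 (0.93 log units; beyond the scatter) both go beyond the scatter, toward weaker inhibition.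

Compound 4 `Cn1c(Cc2nn(CCCO[Si](C)(C)C(C)(C)C)c(=O)c3ccccc23)nnc1SCCCCCCCC(=O)Nc1ccc(Cl)cc1Cl` differs from compound 1 by a group of 10 heavy atoms (8 carbon, 1 oxygen, 1 silicon; no ring) in place of a hydrogen atom, on a saturated chain carbon bound to an aromatic nitrogen. The step that bears on it most directly is an at least 7.6-fold higher number from compound 1 to compound 3 (0.88 log units; beyond the scatter), where a group entered at the same place, on a saturated chain carbon bound to an aromatic nitrogen, and the number rose beyond the scatter. Among the compounds with values here, the group entering in compound 4 carries no net charge and one hydrogen-bond acceptor, unlike the carboxymethyl of compound 3, so a smaller rise is expected than the one to compound 3. The expected step is a 2.3-fold higher number from compound 1 to compound 4 (0.36 log units; beyond the scatter), an upward move in this assay. Compound 4 is therefore estimated at 9000 nM, within 3000 nM to 30000 nM.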

Compound 4, half-maximal inhibitory concentration: > 30000 nM
Compound 4: only a limit was reported; the forecaster's own chance of this, stated with the estimate: 25%; middle value at least 3.3-fold (0.52 log units) from the limit.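

In this assay, the step of an at least 7.6-fold higher number from compound 1 to compound 4 (0.88 log units; beyond the scatter) comes with a group that carries no net charge, so a rise at this place, on a saturated chain carbon bound to an aromatic nitrogen, is not confined to the carboxymethyl of compound 3. Compound 4 is reported only as a limit, and compound 3 stands at the same limit: the limit of > 30000 nM in this assay, at which 2 of the 4 values shown sit. The full size of each rise therefore cannot be read, and the two groups cannot be ranked against each other.

The compounds shown leave open whether a small group at this place, such as a methyl or a 3-hydroxypropyl chain, would stay close to compound 1 at 3900 nM. They also leave open whether an amine there would behave like the two groups shown.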